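Sulfonylamidine naphthoquinone series: aryl removal on the amine nitrogen

The source may hold more compounds than are shown below. What is called first, only, known or untested is meant among the compounds shown, and "the series" means these compounds.

Measured compounds:
- compound 1 `Cc1ccc(S(=O)(=O)/N=C(/CCNC2=CC(=O)c3ccccc3C2=O)Nc2ccc(Cl)cc2)cc1`: 32400 nM
- compound 2 `Cc1ccc(S(=O)(=O)/N=C(/CCNC2=CC(=O)c3ccccc3C2=O)Nc2ccccc2[N+](=O)[O-])cc1`: 7590 nM
- compound 3 `COc1cc(N/C(CCNC2=CC(=O)c3ccccc3C2=O)=N\S(=O)(=O)c2ccc(C)cc2)cc(OC)c1OC`: 9330 nM

In a functional assay on DU-145 cells (Homo sapiens) for cytotoxicity, read by MTT assay, with a stated time of 48 h (on this read-out higher numbers stand for weaker inhibition and lower numbers for stronger inhibition), compound 3 gives 9330 nM and stands second highest of the three numbers; its nearest neighbour is compound 2, at 7590 nM, with the difference a 1.2-fold higher number from compound 2 to compound 3 (0.09 log units; within the scatter), and its furthest is compound 1, with the difference a 3.5-fold lower number from compound 1 to compound 3 (0.54 log units; beyond the scatter). The two aryl changes seen so far, a 4.3-fold lower number from compound 1 to compound 2 (0.63 log units; beyond the scatter) and a 3.5-fold lower number from compound 1 to compound 3 (0.54 log units; beyond the scatter), are both modest.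

Compound 4 `Cc1ccc(S(=O)(=O)/N=C(\N)CCNC2=CC(=O)c3ccccc3C2=O)cc1` differs from compound 3 by hydrogen in place of 3,4,5-trimethoxyphenyl on an amine nitrogen. Among the compounds with values here, no measured step bears directly on removing the aryl group altogether; the steps at hand only exchange one aryl group for another, and they moved the numbers modestly. With the whole aryl group gone, compound 4 is expected to move toward a higher number, by roughly a 2.7-fold higher number from compound 3 to compound 4 (0.43 log units; beyond the scatter), though the uncertainty is wide. For compound 4 the estimated value in this assay is 25000 nM, within a range of 6000 nM to 90000 nM.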

Compound 4, half-maximal inhibitory concentration: 30900 nM
The estimate for compound 4 lay 1.2-fold (0.09 log units) below the measured number; measured number inside the range.
By their numbers in this assay, from the lowest: compounds 2 and 3 (each within the scatter of the next); then compounds 4 and 1 (each within the scatter of the next).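

In this assay, removing the aryl group gives a higher number against 3,4,5-trimethoxyphenyl (a 3.3-fold higher number from compound 3 to compound 4 (0.52 log units; beyond the scatter)) and against 2-nitrophenyl (a 4.1-fold higher number from compound 2 to compound 4 (0.61 log units; beyond the scatter)), but no readable change against 4-chlorophenyl (a 1.0-fold lower number from compound 1 to compound 4 (0.02 log units; within the scatter)). An aryl group on this amine nitrogen is therefore not enough by itself to give a lower number than hydrogen: compound 2 and compound 3 do so, while compound 1 goes against any such general pattern. Nothing measured here accounts for these differences.

From the compounds shown here alone, it remains open whether a small alkyl group such as methyl, or a benzyl group, on this nitrogen would read like hydrogen or like the 2-nitrophenyl and 3,4,5-trimethoxyphenyl groups. Unsubstituted phenyl would show whether the ring alone or its substituents separate compound 1 from compound 2 and compound 3.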